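From tert-butyl to 4-fluorophenyl on the ester carbonyl

A few compounds are considered here, and "the series" means these few. Any claim that something is new, unique, unknown or untested is made for them only; others in the source may bear on it.

Compound 1 `CC(C)CC(=O)O[C@H]1C[C@@H](C)C=C2C=C[C@H](C)[C@H](CC[C@@H]3C[C@@H](O)CC(=O)O3)C21`: 5.4 nM
Compound 2 `C[C@H]1C=C2C=C[C@H](C)[C@H](CC[C@@H]3C[C@@H](O)CC(=O)O3)C2[C@@H](OC(=O)C(C)(C)C)C1`: 2.7 nM

In an assay for inhibition of 3-hydroxy-3-methylglutaryl-coenzyme A reductase (Rattus norvegicus) (on this read-out lower numbers stand for stronger inhibition and higher numbers for weaker inhibition), compound 2 gives the lowest of the two numbers measured, but the step of a 2.0-fold lower number from compound 1 to compound 2 (0.30 log units; within the scatter) lies within the scatter, so compound 1 and compound 2 cannot be told apart on these data. Compound 3 `C[C@H]1C=C2C=C[C@H](C)[C@H](CC[C@@H]3C[C@@H](O)CC(=O)O3)C2[C@@H](OC(=O)c2ccc(F)cc2)C1` differs from compound 2 by 4-fluorophenyl in place of tert-butyl on a carbonyl carbon. Within the data shown here, only one measured step touches this position, and it is the small step from compound 1 to compound 2 just named, which swaps one branched alkyl group for another. Among the measured compounds shown here, no measured pair shows what an aromatic ring does on this carbonyl carbon, so the expectation rests on that single small step alone. The step of a 1.5-fold higher number from compound 2 to compound 3 (0.17 log units; within the scatter) is therefore expected to stay within the scatter, with a wide range to allow for the untested ring. Compound 3 is estimated at 4 nM, between 1.2 nM and 15 nM.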

Compound 3, half-maximal inhibitory concentration: 37 nM
The estimate for compound 3 lay 9.3-fold (0.97 log units) below the measured number, and the stated range ends below it.
By their numbers in this assay, from the lowest: compounds 2 and 1 (each within the scatter of the next); then compound 3.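

In this assay this position proves not to accept every group alike: swapping one branched alkyl group for another had stayed within the scatter, but 4-fluorophenyl on the carbonyl carbon gives a 14-fold higher number from compound 2 to compound 3 (1.14 log units; beyond the scatter) and a 6.9-fold higher number from compound 1 to compound 3 (0.84 log units; beyond the scatter). Both steps lie beyond the scatter, so compound 3 is the weakest of the three, and the group on this carbonyl carbon does matter on this read-out. Nothing available here explains why the aromatic group gives the higher number.

Going by these compounds, it remains open whether the change follows the ring itself or its fluorine, a question that a plain phenyl group would help to settle. On these data alone, it is also open whether a cyclohexyl group, a ring that is not aromatic, would read like the alkyl groups or like 4-fluorophenyl.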